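The compounds below may be only part of what the source reports. "The series", "measured", "known", "first", "only" and "open" are said of these compounds alone.

Compound 1 `CC1=C(C(=O)Nc2ccc(F)cc2)C(c2ccc([N+](=O)[O-])cc2)N=C(SCc2ccccc2)N1` is the reference point of this small set. In a functional assay on the whole organism (artery, strain albino) with Rattus norvegicus as the target, with a stated time of 600 min, at a dose of 10 mg/kg by the oral route (on this read-out higher numbers stand for more inhibition at the one dose given (going by the name of the read-out) and lower numbers for less inhibition), compound 1 gives 32.3%. Going by the values given here, compound 2 `CC1=C(C(=O)Nc2ccc(F)cc2)C(c2ccc([N+](=O)[O-])cc2)N=C(SCc2cccc(Cl)c2)N1` carries the change (chloro in place of hydrogen on an aromatic carbon), and in this assay compound 2 gives 16.4%; the step of a number 15.9 percentage points lower from compound 1 to compound 2 (beyond the scatter) is the only measured step of its kind here. Compound 3 `CC1=C(C(=O)Nc2ccc(Br)cc2)C(c2ccc(Cl)cc2Cl)N=C(SCc2ccccc2)N1` rests on a different core; the difference between the two cores is not broken down here. In this assay compound 3 gives 17.4%, which sits within the usual scatter of compound 2 and clearly below compound 1.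

Compound 4 `CC1=C(C(=O)Nc2ccc(Br)cc2)C(c2ccc(Cl)cc2Cl)N=C(SCc2ccccc2Cl)N1` is built from compound 3 by the change (chloro in place of hydrogen on an aromatic carbon). This is the same kind of change as that from compound 1 to compound 2, not the same one: in compound 2 the entering chloro stands meta to a large group, whereas in compound 4 it stands ortho to a large group. Among the compounds with values here, because the only measured example, a number 15.9 percentage points lower from compound 1 to compound 2 (beyond the scatter), lowered the read-out, a step of about a number 9.4 percentage points lower from compound 3 to compound 4 (within the scatter) is expected from compound 3 to compound 4, with little certainty given the changed position. Compound 4 is therefore estimated to give 8%, between -6% and 24%.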

Compound 4, a percentage reported as inhibition, in the whole organism at one dose (the size of the read-out at that dose, not a potency): 24.6%
The estimate for compound 4 lay 16.6 percentage points below the measured number; measured number above the stated range.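

In this assay, the change of chloro in place of hydrogen on an aromatic carbon brought a number 7.2 percentage points higher from compound 3 to compound 4 (within the scatter), so compound 4 cannot be told apart from compound 3 on this read-out. The two measured cases show that this change does not carry over from one core to the other as a fixed step: the same change on two cores in this assay, a number 15.9 percentage points lower (beyond the scatter) from compound 1 to compound 2 and a number 7.2 percentage points higher (within the scatter) from compound 3 to compound 4, 23.1 percentage points apart, beyond the scatter of two such steps. Going by these compounds alone, this does not show that the core alone is responsible, since in compound 4 the chloro stands ortho to a large group, which is not where it stands in compound 2, and core and place therefore differ together across only two pairs.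

The compounds shown leave open what the same chloro placement would give on both cores, which would separate the two factors. They also leave open how a methoxy group, an amine or a carboxylic acid on the benzyl group would read, and what a longer chain in place of benzyl would give.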